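The source may report more compounds than this note shows. Statements on the series, on what has been measured and on what is new or still open speak of the compounds shown alone.

Measured in an ADME assay for acid dissociation; a higher number here means a more potent compound, by a factor of ten per unit of this negative logarithm, a lower number a less potent compound:
- compound 1 `COc1cc(C(=O)O)ccc1Cc1cn(C2CCCC2)c2ccc(NC(=O)OC3CCCC3)cc12`: 7.67
- compound 2 `COc1cc(C(=O)NS(=O)(=O)c2ccccc2)ccc1Cc1cn(C2CCCC2)c2ccc(NC(=O)OC3CCCC3)cc12`: 7.84
- compound 3 `COc1cc(C(=O)NS(=O)(=O)c2ccccc2)ccc1Cc1c[nH]c2ccc(NC(=O)OC3CCCC3)cc12`: 9.84

Compound 3, at 9.84, stands highest of the three, and its gaps to both others lie beyond the scatter. Compound 4 `COc1cc(C(=O)O)ccc1Cc1c[nH]c2ccc(NC(=O)OC3CCCC3)cc12` has hydroxy in place of (phenylsulfonyl)amino on a carbonyl carbon. The same exchange, run the other way, gave a number 0.17 log units higher from compound 1 to compound 2 (within the scatter), a small step within the scatter, though with cyclopentyl on the aromatic nitrogen. The large step of a number 2.00 log units higher from compound 2 to compound 3 (beyond the scatter) replaced that cyclopentyl with hydrogen, which compound 4 keeps. No step beyond the scatter is therefore expected in this assay, at most a slight fall. The estimated step is a number 0.24 log units lower from compound 3 to compound 4 (within the scatter). Compound 4 is expected at 9.6, with an estimated range of 8.9 to 10.1.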

Compound 4, negative logarithm of the antagonist equilibrium constant: 7.32
For compound 4 the middle estimate is 2.28 log units above the measured one; measured number outside the range, below it.
By their numbers in this assay, from the lowest: compound 4; then compounds 1 and 2 (each within the scatter of the next); then compound 3.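

On the core with hydrogen on the aromatic nitrogen, hydroxy in place of (phenylsulfonyl)amino on a carbonyl carbon gives a number 2.52 log units lower from compound 3 to compound 4 (beyond the scatter) in this assay, so the exchange that stayed within the scatter with cyclopentyl on that nitrogen is large here. With hydroxy kept, hydrogen in place of cyclopentyl gives a number 0.35 log units lower from compound 1 to compound 4 (beyond the scatter), opposite in direction to the same change with (phenylsulfonyl)amino present: the same change on two cores in this assay, a number 2.00 log units higher (beyond the scatter) from compound 2 to compound 3 and a number 0.35 log units lower (beyond the scatter) from compound 1 to compound 4, 2.35 log units apart, beyond the scatter of two such steps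

The two groups therefore act together, and neither step carries over to the other core: the same change on two cores in this assay, a number 0.17 log units higher (within the scatter) from compound 1 to compound 2 and a number 2.52 log units higher (beyond the scatter) from compound 4 to compound 3, 2.35 log units apart, beyond the scatter of two such steps

The compounds shown leave open whether this dependence holds with a methyl group on the aromatic nitrogen, or with (methylsulfonyl)amino or an amine on the carbonyl carbon.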